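A few compounds are considered here, and "the series" means these few. Any claim that something is new, unique, unknown or untested is made for them only; others in the source may bear on it.

Working notes on the series. The shared core carries a hydrazone linked to a substituted benzoyl group. Compound 1 `COc1ccc(C(=O)N/N=C/C2=Cc3ccccc3OC2)cc1` bears a methoxy on the benzoyl ring and hydrogen at the saturated ring position; in a toxicity assay on HEK-293T cells (Homo sapiens) for cytotoxicity, read by MTT assay, with a stated time of 72 h (a lower number here means a stronger inhibitor, a higher number a weaker inhibitor), compound 1 gives 36000 nM. Compound 2 `COc1ccc(C(=O)N/N=C/C2=Cc3ccccc3OC2C)cc1`, the methyl analogue, has in this assay for compound 2 only the entry "not determined" (no result reported), so no number is available for it. Compound 3 `O=C(N/N=C/C1=Cc2ccccc2OC1c1ccccc1)c1ccc(Cl)cc1` combines a chloro on the benzoyl ring with a phenyl at the saturated position; in this assay compound 3 gives 13200 nM, the lowest of the two numbers available, with compound 1 as the nearest neighbour and that gap beyond the scatter. Compound 4 `COc1ccc(C(=O)N/N=C/C2=Cc3ccccc3OC2c2ccccc2)cc1` is reached from compound 3 by methoxy in place of chloro on an aromatic carbon. Within the data shown here, no single-change step between measured compounds exists, so the effect of this swap is unmeasured; compound 1, which carries the same methoxy, gives 36000 nM, and a modest rise toward that value is expected, a 1.7-fold higher number from compound 3 to compound 4 (0.22 log units; within the scatter). Compound 4 is therefore estimated at 22000 nM, range 9000 nM to 55000 nM.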

Compound 4, half-maximal inhibitory concentration: 90700 nM
For compound 4 the middle estimate is 4.1-fold (0.62 log units) below the measured one; measured number outside the range, above it.
By their numbers in this assay, from the lowest: compound 3; then compound 1; then compound 4.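

In this assay, among these compounds, with the phenyl held at the saturated ring carbon, methoxy in place of chloro on the aromatic carbon gives a 6.9-fold higher number from compound 3 to compound 4 (0.84 log units; beyond the scatter) and so provides the first single-change reading at this position: 4-chlorophenyl to 4-methoxyphenyl goes toward weaker inhibition. With the methoxy held, phenyl in place of hydrogen on the saturated ring carbon gives a 2.5-fold higher number from compound 1 to compound 4 (0.40 log units; beyond the scatter) and so shows that this second position also affects the number, again toward weaker inhibition. The change on the aromatic carbon is the larger of the two steps in its printed size, and both are beyond the scatter.

On these data alone, whether the chloro to methoxy step keeps its size with hydrogen rather than phenyl on the saturated ring carbon stays open. So does the reading for an amine or a carboxylic acid on the aromatic carbon, or a longer chain on the saturated ring carbon. No measurement at hand bears on the cause of either step.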